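The source may report more compounds than this note shows. Statements on the series, on what has been measured and on what is new or still open speak of the compounds shown alone.

Compound 1, `COc1ccc(-c2cc(C(=O)Nc3ccc(Oc4ccnc5[nH]ccc45)cc3)ncn2)cc1`, in a functional assay on MCF7 cells (Homo sapiens) for cytotoxicity, read by MTT assay, with a stated time of 72 h (a lower number here means a stronger inhibitor, a higher number a weaker inhibitor), compound 1 gives 4450 nM.
Compound 2, `O=C(Nc1ccc(Oc2ccnc3[nH]ccc23)cc1)c1cc(-c2ccc(Cl)cc2)ncn1`, in this assay compound 2 gives 7770 nM.
Compound 3, `COc1ccc(-c2ccnc(C(=O)Nc3ccc(Oc4ccnc5[nH]ccc45)c(F)c3)n2)cc1`, in this assay compound 3 gives 8960 nM.

Compound 1 and compound 2 share one core and differ in a single place. The change is chloro in place of methoxy on an aromatic carbon. In this assay this gave a 1.7-fold higher number from compound 1 to compound 2 (0.24 log units; within the scatter), so the two numbers cannot be told apart with confidence.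

Compound 3 is built on a different core, and how that core differs from the core of compound 1 is not broken down here. Its value in this assay sits close to those of compound 1 and compound 2, with all three within the scatter of one another.

Compound 4, `O=C(Nc1ccc(Oc2ccnc3[nH]ccc23)c(F)c1)c1nccc(-c2ccc(Cl)cc2)n1`, has not yet been measured. It stands to compound 3 as compound 2 stands to compound 1: the change is chloro in place of methoxy on an aromatic carbon. The place is described in the same words for both pairs, so this is the same change made on a second core.

Within the data shown here, because the only precedent, a 1.7-fold higher number from compound 1 to compound 2 (0.24 log units; within the scatter), was small, a step of similar size is expected here, a 1.7-fold higher number from compound 3 to compound 4 (0.22 log units; within the scatter), an expectation that rests solely on that one earlier pair. Compound 4 is therefore expected to give about 15000 nM in this assay. Given the uncertainty of carrying a single observation across cores, compound 4 is estimated to fall between 5000 nM and 45000 nM.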

Compound 4, half-maximal inhibitory concentration: 9660 nM
Estimate against measurement, compound 4: 1.6-fold (0.19 log units) above; low and high end bracket the measured number.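

Changing 4-methoxyphenyl to 4-chlorophenyl on the second core gave a 1.1-fold higher number from compound 3 to compound 4 (0.03 log units; within the scatter), so in this assay compound 3 and compound 4 cannot be told apart with confidence. Set beside the earlier pair, the change gives no sign of behaving differently on the two cores: the same change on two cores in this assay, a 1.7-fold higher number (0.24 log units; within the scatter) from compound 1 to compound 2 and a 1.1-fold higher number (0.03 log units; within the scatter) from compound 3 to compound 4, 1.6-fold (0.21 log units) apart, within the scatter of two such steps This shows that, in this one cell assay, the swap left the number within the usual scatter on both cores, but it does not show that the swap is without effect in general, that it would behave the same way on a third core, or that it would carry over to any other kind of measurement, and two small steps that agree are only a weak test of transfer.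

The compounds shown carry only methoxy or chloro at this spot on the carbon-only aromatic ring, so it remains open whether a quite different group there, such as an amine, a carboxylic acid or a longer chain, would move the number beyond the scatter. Also open, going by these compounds, is which part of the difference between the two cores matters, since the core of compound 1 and the core of compound 3 are compared here only through this one swap.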